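Dropping the Para Substituent: Compound 2 to Compound 3

A few compounds are considered here, and "the series" means these few. Any claim that something is new, unique, unknown or untested is made for them only; others in the source may bear on it.

In a functional assay on MCF7 cells (Homo sapiens) for inhibition (a lower number here means a stronger inhibitor, a higher number a weaker inhibitor), compound 2 `N#CC1CN1C(=O)Nc1ccc([N+](=O)[O-])cc1` gives 3000 nM, and compound 1 `CCOC(=O)c1ccc(NC(=O)N2CC2C#N)cc1` gives 2300 nM; the two numbers lie within the scatter of each other. Compound 3 `N#CC1CN1C(=O)Nc1ccccc1` differs from compound 2 by hydrogen in place of nitro on an aromatic carbon, para to a group of 8 heavy atoms. Among the measured compounds shown here, the only step that touches this place, a 1.3-fold higher number from compound 1 to compound 2 (0.12 log units; within the scatter), swapped one group for another without leaving the scatter. For the measured compounds named here, removing the group entirely has no precedent here, so no step beyond the scatter is expected, no change at the digits printed from compound 2 to compound 3 (within the scatter). Compound 3 is therefore estimated at 3000 nM, within a range from 1000 nM to 9000 nM.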

Compound 3, half-maximal inhibitory concentration: 2900 nM
The estimate for compound 3 lay 1.0-fold (0.01 log units) above the measured number; low and high end bracket the measured number.
By their numbers in this assay, from the lowest: compounds 1, 3 and 2 (each within the scatter of the next).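

In this assay, removing the group altogether and leaving hydrogen on the aromatic carbon stays within the scatter, whether nitro leaves (a 1.0-fold lower number from compound 2 to compound 3 (0.01 log units; within the scatter)) or ethoxycarbonyl leaves (a 1.3-fold higher number from compound 1 to compound 3 (0.10 log units; within the scatter)). The earlier step only replaced one group with another, whereas these steps show that neither group is needed at this position to keep the number within the scatter. No evidence is available to explain this result. Going by these compounds, it remains open whether an amine or a carboxylic acid at this position would also stay within the scatter.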